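This account rests on a few compounds, and the source may have more. Where it says the series, first, only, none or still open, it means among the compounds named here.

Compound 1, `CN(CC(=O)N1CCN(c2ccc(F)cc2)CC1)C(=O)c1ccc(S(C)(=O)=O)c([N+](=O)[O-])c1`: in an assay on isolated protein for inhibition of thyroid hormone receptor alpha (Homo sapiens), read by fluorescence polarization (on this read-out lower numbers stand for stronger inhibition and higher numbers for weaker inhibition), compound 1 gives > 60000 nM, which is a limit of the assay and not a number.
Compound 2, `CS(=O)(=O)c1ccc(C(=O)N2CCC(C(=O)N3CCC(c4ccccc4)CC3)CC2)cc1[N+](=O)[O-]`: in this assay compound 2 gives > 60000 nM, likewise a limit.
Compound 3, `CN(CC(=O)N1CCN(c2ccccc2)CC1)C(=O)c1ccc(S(C)(=O)=O)c([N+](=O)[O-])c1`: in this assay compound 3 gives > 60000 nM, again a limit.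

Compound 3 therefore stands at the limit of the assay, with no number of its own, and the same holds for the other two compounds, so none of the three can be ranked against another. Within the data shown here, the single one-place step among the measured compounds, a step that the two limits leave unreadable from compound 1 to compound 3, cannot be sized, because of the limit of > 60000 nM in this assay, at which 3 of the 3 values shown sit. Compound 4, `CN(CC(=O)N1CCN(c2ccc(C(F)(F)F)cc2)CC1)C(=O)c1ccc(S(C)(=O)=O)c([N+](=O)[O-])c1`, differs from compound 3 by trifluoromethyl in place of hydrogen on an aromatic carbon. Among the measured compounds shown here, no measured step bears directly on this change, and the one step that exists gives no readable size. The step from compound 3 to compound 4 is therefore expected to stay unreadable, a number no higher from compound 3 to compound 4 (the limit leaves the size open), with compound 4 most likely reported again as a limit. Compound 4 is estimated at 60000 nM, within a range of 20000 nM to 200000 nM.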

Compound 4, half-maximal inhibitory concentration: > 60000 nM
Compound 4: no number, only a limit (the forecaster's own chance of this, stated with the estimate: 85%); the middle value sits exactly at the limit.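

Compound 4 gives > 60000 nM, again a limit of the assay and not a number. The steps to compound 4 from compound 1 and from compound 3 therefore cannot be read: the limit of > 60000 nM in this assay, at which 4 of the 4 values shown sit. The compounds shown leave open whether hydrogen, fluoro and trifluoromethyl differ at all in this assay.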